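Swapping Fluorine for Methyl on a Cyclopropyl Amide

A few compounds are considered here, and "the series" means these few. Any claim that something is new, unique, unknown or untested is made for them only; others in the source may bear on it.

Two amides of a shared core have been measured in an assay on SH-EP1 cells for agonist activity at Neuronal acetylcholine receptor; alpha4/beta2 (Homo sapiens), read by FLIPR and calcium flux; on this read-out higher numbers stand for an effect only at larger amounts of compound and lower numbers for an effect already at smaller amounts. Compound 1 `O=C(C1CCC1)N1CC2CC(C1)N2` carries a cyclobutyl on the carbonyl carbon, and in this assay compound 1 gives 11000 nM. Compound 2 `O=C([C@@H]1C[C@H]1F)N1CC2CC(C1)N2` carries a 2-fluorocyclopropyl instead, and compound 2 gives 870 nM. Among the compounds with values here, the single measured step is a 13-fold lower number from compound 1 to compound 2 (1.10 log units; beyond the scatter). Among the two numbers known so far, compound 2 therefore stands as the lowest. Compound 3 `C[C@@H]1C[C@H]1C(=O)N1CC2CC(C1)N2` is not yet measured; it differs from compound 2 by methyl in place of fluoro on a saturated ring carbon. Within the data shown here, no measured step replaces fluoro with methyl: the one step available changes ring size and fluorine together, so it bears on this change only loosely. The expected step is therefore modest, a 1.7-fold higher number from compound 2 to compound 3 (0.24 log units; within the scatter), toward a somewhat higher number, with wide uncertainty. The estimate for compound 3 is 1500 nM, with a range from 500 nM to 5000 nM.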

Compound 3, half-maximal effective concentration: 2900 nM
Beside the measured number, compound 3's estimate is 1.9-fold (0.29 log units) below it; the measured number falls inside the stated range.
By their numbers in this assay, from the lowest: compound 2; then compound 3; then compound 1.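

In this assay holding the ring size fixed gives a 3.3-fold higher number from compound 2 to compound 3 (0.52 log units; beyond the scatter) so at this saturated ring carbon the choice between fluoro and methyl matters on its own, with fluoro going with the lower number. Set against the cyclobutyl amide, the methyl compound gives a 3.8-fold lower number from compound 1 to compound 3 (0.58 log units; beyond the scatter) which shows that a number lower than the cyclobutyl amide's does not depend on fluorine being present. Nothing available here explains the difference between fluoro and methyl.

Still open, going by these compounds, is where a plain cyclopropyl amide, with only hydrogen at this ring carbon, would fall relative to the fluoro and methyl compounds. Also open, on these data alone, is how a hydroxyl, an ethyl or a trifluoromethyl on the same ring carbon would compare, and whether the opposite arrangement of the two ring groups would keep the same order.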